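A Repeated Chloro Step Within the Usual Scatter

This account rests on a few compounds, and the source may have more. Where it says the series, first, only, none or still open, it means among the compounds named here.

Three compounds have been measured in a functional assay on M14 cells (Homo sapiens) for cytotoxicity, read by sulforhodamine B assay, with a stated time of 48 h; on this read-out higher numbers stand for weaker inhibition of growth and lower numbers for stronger inhibition of growth:

Compound 1, `ClCc1ccccc1Cn1cnc2c(Cl)nc(Cl)nc21`: 1380 nM
Compound 2, `ClCc1ccccc1Cn1cnc2c(Cl)ncnc21`: 1950 nM
Compound 3, `ClCc1cccc(Cn2cnc3ncnc(Cl)c32)c1`: 3090 nM

Compound 2 and compound 1 differ in one place, (chloro in place of hydrogen on an aromatic carbon), and this change gave a 1.4-fold lower number from compound 2 to compound 1 (0.15 log units; within the scatter). Compound 3 gives the highest of the three numbers; against compound 2 the gap is within the scatter, and only against compound 1 does it lie beyond it. Compound 3 and compound 2 hold the same atoms joined differently, and the difference between the two cores is not broken down here.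

Compound 4, `ClCc1cccc(Cn2cnc3nc(Cl)nc(Cl)c32)c1`, has not yet been measured. It differs from compound 3 by chloro in place of hydrogen on an aromatic carbon, and the place of this change reads the same, word for word, as the place of the change from compound 2 to compound 1, so the two are the same change made on two different cores. In this assay the step from compound 3 to compound 4 is expected to be a 1.4-fold lower number from compound 3 to compound 4 (0.15 log units; within the scatter), about as small as the earlier one, because the same change gave a 1.4-fold lower number from compound 2 to compound 1 (0.15 log units; within the scatter), a step within the scatter. On that basis compound 4 is estimated at 2200 nM, with a range from 1000 nM to 4800 nM expected to hold most repeat measurements.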

Compound 4, concentration for 50% growth inhibition: 1380 nM
For compound 4 the middle estimate is 1.6-fold (0.20 log units) above the measured one, within the range that was stated.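

In this assay, chloro in place of hydrogen on an aromatic carbon between two ring nitrogen atoms gave a 2.2-fold lower number from compound 3 to compound 4 (0.35 log units; beyond the scatter), a modest step that lies beyond the scatter. Among the compounds shown here, although the earlier step on the other core stays within the scatter, that contrast is not a real difference between the cores, and the change can be said to carry across them with the same direction and no separable difference in size: the same change on two cores in this assay, a 1.4-fold lower number (0.15 log units; within the scatter) from compound 2 to compound 1 and a 2.2-fold lower number (0.35 log units; beyond the scatter) from compound 3 to compound 4, 1.6-fold (0.20 log units) apart, within the scatter of two such steps This rests on only two matched pairs, so it does not show that the step has a fixed size, that it would hold on any further core, or why the number moves at all.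

The compounds shown leave open whether an amine or a methoxy group at this same place would shift the number in the same direction as chloro, or whether only chloro does so on these two cores. With a single cell line and a single read-out in view, they also leave open whether the chloro step would look the same in any other test of growth inhibition.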